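This account rests on a few compounds, and the source may have more. Where it says the series, first, only, none or still open, it means among the compounds named here.

Measured compounds:
Compound 1, `CCC(=O)Nc1ccc(S(=O)(=O)Oc2ccccc2I)cc1` — in a functional assay on HT-1080 cells (Homo sapiens) for antiproliferative activity, read by sulforhodamine B assay, with a stated time of 48 h (a higher number here means a weaker inhibitor, a lower number a stronger inhibitor), compound 1 gives 7200 nM.
Compound 2, `CCCC(=O)Nc1ccc(S(=O)(=O)Oc2ccccc2C(C)C)cc1` — in this assay compound 2 gives 950 nM.

Compound 2 holds the lower of the two numbers; compound 1 sits a good deal higher, and that gap is beyond the usual scatter. Within the data shown here, the two differ in more than one place, so no single step between them can be read off.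

Compound 3, `CCCC(=O)Nc1ccc(S(=O)(=O)Oc2ccccc2I)cc1`, has not yet been measured in this assay. It comes from compound 2 by one change: iodo in place of isopropyl on an aromatic carbon. Among the measured compounds shown here, the only guide is that compound 1, which carries the same iodo group, gives 7200 nM, well above compound 2. The step is therefore expected to go upward, toward weaker inhibition, by a 3.7-fold higher number from compound 2 to compound 3 (0.57 log units; beyond the scatter), most likely beyond the scatter. Compound 3 is accordingly estimated at 3500 nM, within a range of 1200 nM to 10000 nM.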

Compound 3, half-maximal inhibitory concentration: 2000 nM
Estimate against measurement, compound 3: 1.8-fold (0.24 log units) above; the range from low to high includes it.
By their numbers in this assay, from the lowest: compound 2; then compound 3; then compound 1.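

In this assay, the aromatic carbon that carries isopropyl in compound 2 takes iodo only at some cost, with iodo in place of isopropyl giving a 2.1-fold higher number from compound 2 to compound 3 (0.32 log units; beyond the scatter) as a modest step. The chain, which could not be separated from the aromatic group in the earlier pair, now has a step of its own: methyl in place of hydrogen on a saturated chain carbon, two bonds along the chain from a carbonyl carbon, gives a 3.6-fold lower number from compound 1 to compound 3 (0.56 log units; beyond the scatter) on the iodo compounds. In these single pairs, each place moves the number by itself, the chain change toward stronger inhibition and the aromatic change toward weaker inhibition.

From the compounds shown here alone, whether the chain step holds with isopropyl on the aromatic carbon stays open. So does the effect of a longer chain, or of an amine or a carboxylic acid on that aromatic carbon.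

No measurement at hand gives a reason for either step.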